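The source may report more compounds than this note shows. Statements on the series, on what has been measured and on what is new or still open speak of the compounds shown alone.

Of the compounds shown here, two have been measured in a physicochemical assay for solubility, read by HPLC, with a stated time of 4 h, at pH 2, tested at 10 mg/mL; a lower number here means a less soluble compound, a higher number a more soluble compound. Compound 1 `Cc1cc(CCC#N)cc(C)c1Oc1cc(Nc2ccc(C#N)cc2)c(N)cc1C(=O)N(C)C` gives 65.1 ug/mL, and compound 2 `Cc1cc(CCC#N)cc(C)c1Oc1cc(Nc2ccc(C#N)cc2)c(N)cc1C(=O)NC1CC1` gives 141 ug/mL. Among the measured compounds shown here, the only measured step is a 2.2-fold higher number from compound 1 to compound 2 (0.34 log units; beyond the scatter). On these two numbers compound 2 stands highest, with compound 1 as its nearest neighbour.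

Compound 3 `CC(=O)OCc1cc(N)c(Nc2ccc(C#N)cc2)cc1Oc1c(C)cc(CCC#N)cc1C` is not yet measured. It differs from compound 2 as follows: acetoxymethyl in place of cyclopropylcarbamoyl on an aromatic carbon. For the measured compounds named here, the one measured step exchanged two groups on a carbonyl carbon while the carbonyl itself stayed; here the whole cyclopropylcarbamoyl gives way to acetoxymethyl on an aromatic carbon, so that step does not bear directly on this change. Going by the values given here, with no relevant step available, no shift beyond the scatter is expected in either direction, and the estimate is left wide: compound 3 is expected to show 100 ug/mL, ranging from 30 ug/mL to 330 ug/mL, which corresponds to an expected step of a 1.4-fold lower number from compound 2 to compound 3 (0.15 log units; within the scatter).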

Compound 3, solubility: 2.63 ug/mL
Compound 3: middle estimate off by 38-fold (1.58 log units), on the high side, outside the stated range (below it).
By their numbers in this assay, from the lowest: compound 3; then compound 1; then compound 2.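

In this assay, the earlier swap between two amides moved the number only modestly, with a 2.2-fold higher number from compound 1 to compound 2 (0.34 log units; beyond the scatter), whereas removing the amide altogether from this aromatic carbon, para to a (4-cyanophenyl)amino group, has a far greater impact. Acetoxymethyl in place of cyclopropylcarbamoyl gives a 54-fold lower number from compound 2 to compound 3 (1.73 log units; beyond the scatter), and acetoxymethyl in place of dimethylcarbamoyl gives a 25-fold lower number from compound 1 to compound 3 (1.39 log units; beyond the scatter), so the large fall appears against both amides. No supporting measurement is available to explain this fall.

Among the compounds shown here, with only one non-amide group at this position, these compounds cannot show which part of the change matters: the loss of the amide or the arrival of the ester. On these data alone, it also remains open whether a hydroxymethyl group or a carboxylic acid here would give a number closer to those of the amides or to that of compound 3.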